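The source may report more compounds than this note shows. Statements on the series, on what has been measured and on what is new or still open speak of the compounds shown alone.

Working notes on the series. The shared core is that of compound 1 `CSc1nc2ccccc2n1C1CCN(CCCC(=O)c2ccc(F)cc2)CC1`, which in a functional assay on the whole organism (strain STD-ddY) with Mus musculus as the target, with stated times of 1 h and 24 h (on this read-out higher numbers stand for an effect only at larger amounts of compound and lower numbers for an effect already at smaller amounts), gives 0.68 mg/kg. Compound 2 `O=C(CCCN1CCC(n2c(SCCO)nc3ccccc32)CC1)c1ccc(F)cc1` carries hydroxymethyl on the saturated chain carbon bound to a sulfur. In this assay compound 2 reaches only a limit, > 3 mg/kg. Compound 3 `O=C(CCCSc1nc2ccccc2n1C1CCN(CCCC(=O)c2ccc(F)cc2)CC1)c1ccc(F)cc1` carries 2-((4-fluorophenyl)carbonyl)ethyl at that same carbon. In this assay compound 3 likewise reaches only a limit, > 3 mg/kg. Both substitutions move the number the same way: an at least 4.4-fold higher number from compound 1 to compound 2 (0.64 log units; beyond the scatter) and an at least 4.4-fold higher number from compound 1 to compound 3 (0.64 log units; beyond the scatter). Between the two substituted compounds the step stays open, a step that the two limits leave unreadable from compound 2 to compound 3, since the limit of > 3 mg/kg in this assay, at which 2 of the 3 values shown sit, covers both. Compound 4 `O=C(CCCN1CCC(n2c(SCc3ccccc3)nc3ccccc32)CC1)c1ccc(F)cc1` arises from compound 3 by the change (phenyl in place of 2-((4-fluorophenyl)carbonyl)ethyl on a saturated chain carbon bound to a sulfur). A substituent on the sulfur-bound carbon remains, so the two steps from compound 1 bear on it and point away from the number of compound 1; the step from the limit of compound 3 itself cannot be read. For compound 4 the expected value in this assay is estimated at 3 mg/kg, between 0.8 mg/kg and 10 mg/kg. That estimate amounts to an expected step of a number no higher from compound 3 to compound 4 (the limit leaves the size open), with a limit again likely.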

Compound 4, dose for half-maximal effect: 0.76 mg/kg
The estimate for compound 4 lay 3.9-fold (0.60 log units) above the measured number; the whole stated range lies above it.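

A substituent on the saturated chain carbon bound to a sulfur does not by itself shift the number in this assay: phenyl there gives a 1.1-fold higher number from compound 1 to compound 4 (0.05 log units; within the scatter). The earlier reading, that substitution at this carbon moves the number up, therefore fits only hydroxymethyl and 2-((4-fluorophenyl)carbonyl)ethyl; compound 4 goes against it, with an at least 3.9-fold lower number from compound 3 to compound 4 (0.59 log units; beyond the scatter) and an at least 3.9-fold lower number from compound 2 to compound 4 (0.59 log units; beyond the scatter). The true sizes of these last two steps remain open, as compound 2 and compound 3 stand only as limits of the assay: the limit of > 3 mg/kg in this assay, at which 2 of the 4 values shown sit.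

Compound 3 also carries a six-membered aromatic ring, so the compounds shown do not separate the roles of its carbonyl, its fluorine and its chain length in this assay. Also open, going by these compounds, is how 2-phenylethyl in place of benzyl, or an amine or a carboxylic acid on the phenyl, would read here.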